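Another Substituted Phenyl on the Amide Nitrogen

The source may report more compounds than this note shows. Statements on the series, on what has been measured and on what is new or still open speak of the compounds shown alone.

For the measured compounds named here, compound 1 `COc1cc2c(cc1OC)C(CC(=O)Nc1cccc(Cl)c1)CC2` was tested in a functional assay on the whole organism (strain Wistar) for inhibition, with Rattus norvegicus as the target, read by paw edema, with a stated time of 3 h, at a dose of 100 mg/kg (on this read-out lower numbers stand for less inhibition and higher numbers for more inhibition at the one dose given (going by the name of the read-out)), where compound 1 gives 24.6%, the lower of the two numbers known so far. Compound 2 `COc1cc2c(cc1OC)C(CC(=O)Nc1ccc(Br)cc1)CC2` gives 43.5%, so the step of a number 18.9 percentage points higher from compound 1 to compound 2 (beyond the scatter). Compound 3 `COc1cc2c(cc1OC)C(CC(=O)Nc1ccccc1C)CC2` differs from compound 1 by 2-methylphenyl in place of 3-chlorophenyl on an amide-type nitrogen. Going by the values given here, the one measured step exchanged the same 3-chlorophenyl for a different substituted phenyl, so it bears only loosely on this change; an expected step of a number 7.4 percentage points higher from compound 1 to compound 3 (within the scatter), small and uncertain in direction, seems reasonable. Compound 3 is therefore expected to give about 32%, ranging from 15% to 50%.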

Compound 3, a percentage reported as inhibition, in the whole organism at one dose (the size of the read-out at that dose, not a potency): 26.1%
The estimate for compound 3 lay 5.9 percentage points above the measured number, within the range that was stated.
By their numbers in this assay, from the lowest: compounds 1 and 3 (each within the scatter of the next); then compound 2.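

In this assay, 2-methylphenyl in place of 3-chlorophenyl on an amide-type nitrogen gives a number 1.5 percentage points higher from compound 1 to compound 3 (within the scatter), while 2-methylphenyl in place of 4-bromophenyl gives a number 17.4 percentage points lower from compound 2 to compound 3 (beyond the scatter), so the two changes differ in outcome. Among these three substituted phenyl groups only 4-bromophenyl stands apart, and a group of carbon only matches the chlorine-bearing one. Nothing available explains this gap.

Each pair changes both the substituent and its place on the ring, so these two influences cannot be separated. From the compounds shown here alone, an unsubstituted phenyl, 4-chlorophenyl or 4-methylphenyl remains open.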